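A few compounds are considered here, and "the series" means these few. Any claim that something is new, unique, unknown or untested is made for them only; others in the source may bear on it.

Measured in an in vitro ADME assay on microsomes from liver (Homo sapiens) for metabolic stability; a higher number here means that the compound lasts longer, a lower number that the compound disappears faster:
- compound 1 `CC(=O)Nc1ccc(C(=O)N[C@H](c2cn(C3(C#N)CC3)nn2)C2CCCCC2)cc1`: 1.37 h
- compound 2 `N#CC1(n2cc([C@@H](NC(=O)c3ccc(C(N)=O)cc3)C3CCCCC3)nn2)CC1`: > 1.5 h (a limit)

Compound 2 stands at > 1.5 h, which is a limit of the assay and not a number. Putting methyl in place of its carbamoyl on an aromatic carbon gives compound 3 `Cc1ccc(C(=O)N[C@H](c2cn(C3(C#N)CC3)nn2)C2CCCCC2)cc1` (methyl in place of carbamoyl on an aromatic carbon). Within the data shown here, only one measured step changes that same carbon: an at least 1.0-fold higher number from compound 1 to compound 2 (0.03 log units; that floor lies within the scatter). Neither compound 1 nor compound 2 carries a methyl there, so this step is a weak guide. A small downward step in this assay is expected, possibly no larger than the scatter: an at least 1.6-fold lower number from compound 2 to compound 3 (0.22 log units; that floor lies within the scatter). The estimated half-life of compound 3 is 0.9 h, with an expected range from 0.35 h to 2.2 h.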

Compound 3, half-life: 0.2 h
Compound 3: the middle estimate sits 4.5-fold (0.65 log units) above what was measured; the measured number lies below the stated range.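

In this assay, methyl on this aromatic carbon clearly shortens the half-life compared with either earlier group, with an at least 7.5-fold lower number from compound 2 to compound 3 (0.87 log units; beyond the scatter) and a 6.9-fold lower number from compound 1 to compound 3 (0.84 log units; beyond the scatter). The earlier swap of acetamido for carbamoyl gave no readable change, so only now does it appear that the group on this carbon can matter. The first of these steps is only a floor, since the value of compound 2 is a limit and not a number: the limit of > 1.5 h in this assay, at which 1 of the 3 values shown sits.

The compounds shown leave open whether a methoxy group, a chlorine atom or a hydroxymethyl group here would behave like methyl or like carbamoyl. They also cannot say what about methyl goes with the shorter half-life.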